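The source may hold more compounds than are shown below. What is called first, only, known or untested is meant among the compounds shown, and "the series" means these compounds.

Of the compounds shown here, three have been measured in a functional assay on A-375 cells (Homo sapiens) for cytotoxicity, read by MTT assay, with a stated time of 72 h, tested at 100 uM; on this read-out lower numbers stand for less inhibition of growth and higher numbers for more inhibition of growth at the one concentration tested. Compound 1 `Cc1ccnc(/C(N)=N/NC(=S)N2CCCC2)c1` gives 88.8%, and compound 3 `N/C(=N\NC(=S)N1CCCCCC1)c1ccccn1` gives 89%. Compound 2 `N/C(=N\NC(=S)N1CCN(c2ccccn2)CC1)c1ccc(F)cn1` stands lowest of the three, giving 76.2%; its nearest neighbour is compound 1, a number higher by more than the usual scatter, and the gap to compound 3 is likewise beyond the scatter. Compound 4 `N/C(=N\NC(=S)N1CCN(c2ccccn2)CC1)c1ccccn1` has not yet been measured in this assay. It differs from compound 2 in one place: hydrogen in place of fluoro on an aromatic carbon. Going by the values given here, no measured pair shows this change alone, so its size in this assay is not known from these numbers. Because compound 3 gives 89% while carrying the same pyridin-2-yl group, a small rise is expected, one that may stay within the scatter. Compound 4 is therefore expected to reach 82%, with a range from 68% to 92%, an expected step of a number 5.8 percentage points higher from compound 2 to compound 4 (within the scatter).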

Compound 4, percent growth inhibition at one concentration: 86.8%
Estimate against measurement, compound 4: 4.8 percentage points below; measured number inside the range.
By their numbers in this assay, from the lowest: compound 2; then compounds 4, 1 and 3 (each within the scatter of the next).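

In this assay, replacing 5-fluoropyridin-2-yl with pyridin-2-yl gives a number 10.6 percentage points higher from compound 2 to compound 4 (beyond the scatter), the first measured size for this change and a sign that this aromatic carbon, two atoms from the ring nitrogen, is not indifferent to its substituent. The reading rests on this single pair, with fluoro on the lower side. Nothing available explains the step. Going by these compounds, whether chloro, methyl or an amine on the same carbon would read like compound 2 or like compound 4 remains open, as does whether the step recurs with the other groups on the shared core.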